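Compound 1 to compound 4: a sulfur-linked methoxybenzyl group

The source may report more compounds than this note shows. Statements on the series, on what has been measured and on what is new or still open speak of the compounds shown alone.

Measured compounds:
compound 1, `CC(C(=O)NCc1ccc(C(F)(F)F)cc1N1CCCCCCC1)c1ccc(NS(C)(=O)=O)c(F)c1`, 2.8 nM
compound 2, `CC(C(=O)NCc1ccc(C(F)(F)F)cc1OCc1ccc(F)cc1)c1ccc(NS(C)(=O)=O)c(F)c1`, 0.5 nM
compound 3, `CCCCSc1cc(C(F)(F)F)ccc1CNC(=O)C(C)c1ccc(NS(C)(=O)=O)c(F)c1`, 1.9 nM

In an assay on CHO cells for antagonist activity at transient receptor potential cation channel subfamily V member 1 (Homo sapiens), read by FLIPR (on this read-out lower numbers stand for stronger inhibition and higher numbers for weaker inhibition), compound 1 gives the highest of the three numbers. Its nearest neighbour is compound 3, a 1.5-fold lower number from compound 1 to compound 3 (0.17 log units; within the scatter); the furthest is compound 2, a 5.6-fold lower number from compound 1 to compound 2 (0.75 log units; beyond the scatter). Compound 4, `COc1ccc(CSc2cc(C(F)(F)F)ccc2CNC(=O)C(C)c2ccc(NS(C)(=O)=O)c(F)c2)cc1`, has not been measured. It differs from compound 1 at one place: a group of 10 heavy atoms (8 carbon, 1 oxygen, 1 sulfur; one six-membered aromatic ring of carbon only) in place of a group of 8 heavy atoms (7 carbon, 1 nitrogen; one eight-membered non-aromatic ring with 1 hetero atom), on an aromatic carbon.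

Among the compounds with values here, two measured steps bear on this change. The step of a 5.6-fold lower number from compound 1 to compound 2 (0.75 log units; beyond the scatter) shows that a benzyl group carried through oxygen at this position gives a modest gain over the eight-membered ring. The step of a 1.5-fold lower number from compound 1 to compound 3 (0.17 log units; within the scatter) shows that a butyl chain carried through sulfur sits within the scatter of compound 1, while a 3.8-fold higher number from compound 2 to compound 3 (0.58 log units; beyond the scatter) shows the benzyl bearer ahead of the butyl one. Compound 4 joins a sulfur link with a benzyl group, so a step in this assay from compound 1 to compound 4 is expected to be downward, a 3.5-fold lower number from compound 1 to compound 4 (0.54 log units; beyond the scatter), and modest. For compound 4 the estimate in this assay is 0.8 nM, within 0.3 nM to 2.5 nM.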

Compound 4, inhibition constant: 2.3 nM
Beside the measured number, compound 4's estimate is 2.9-fold (0.46 log units) below it, and the stated range covers the measured number.
By their numbers in this assay, from the lowest: compound 2; then compounds 3, 4 and 1 (each within the scatter of the next).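

In this assay, the gain that (4-fluorobenzyl)oxy gave over the eight-membered ring does not carry over to (4-methoxybenzyl)sulfanyl: the new group leaves the number level with that ring (a 1.2-fold lower number from compound 1 to compound 4 (0.09 log units; within the scatter)) and clearly behind the oxygen-linked group (a 4.6-fold higher number from compound 2 to compound 4 (0.66 log units; beyond the scatter)). With the sulfur link in place, 4-methoxyphenyl in place of propyl also makes no difference that can be told from the scatter (a 1.2-fold higher number from compound 3 to compound 4 (0.08 log units; within the scatter)). A benzyl group at this position is therefore not enough by itself to match compound 2, which alone stands apart from the other three compounds.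

Nothing shown gives a reason for this result. Going by these compounds, compound 2 and compound 4 differ in both the linking atom and the ring substituent, so it remains open which of these matters, and how (4-fluorobenzyl)sulfanyl or a benzylamino group would read.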